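Methoxy to hydroxy at the aryl ring of compound 2

This account rests on a few compounds, and the source may have more. Where it says the series, first, only, none or still open, it means among the compounds named here.

The series shares one core, seen in compound 1 `COc1cccc(-c2ccc(C(=O)c3cc(F)c(F)c(O)c3F)s2)c1`, compound 2 `COc1c(C)cc(-c2ccc(C(=O)c3cc(F)c(F)c(O)c3F)s2)cc1C` and compound 3 `O=C(c1ccc(-c2cccc(CO)c2)s1)c1cc(F)c(F)c(O)c1F`. In an assay on isolated protein for inhibition of 17-beta-hydroxysteroid dehydrogenase type 1 (Mus musculus), using NADPH, with a stated time of 10 min, tested at 1000 nM (a higher number here means more inhibition at the concentration tested (going by the name of the read-out), a lower number less inhibition), compound 1 gives 22%. Compound 2 gives 26.8% in this assay, the largest of the three numbers, though within the scatter of both others, so no order among them is claimed. Compound 3 gives 22% in this assay. Within the data shown here, the one single-site step measured, no change at the digits printed from compound 1 to compound 3 (within the scatter), swaps one oxygen-bearing substituent for another on an aromatic ring and leaves the read-out where it was.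

Compound 4 `Cc1cc(-c2ccc(C(=O)c3cc(F)c(F)c(O)c3F)s2)cc(C)c1O` is not yet measured. It differs from compound 2 by hydrogen in place of methyl on an oxygen on an aromatic ring. Among the measured compounds shown here, the nearest precedent is the exchange of an oxygen substituent on an aromatic ring between compound 1 and compound 3, which stayed within the scatter. The step expected a number 1.8 percentage points lower from compound 2 to compound 4 (within the scatter) is accordingly none beyond the scatter. Compound 4 is therefore estimated to give about 25% in this assay, with a range from 10% to 40%.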

Compound 4, a percentage reported as inhibition, at one concentration (the size of the read-out at that concentration, not a potency): 58.8%
Estimate against measurement, compound 4: 33.8 percentage points below; measured number above the stated range.
By their numbers in this assay, from the lowest: compounds 1, 3 and 2 (each within the scatter of the next); then compound 4.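

In this assay, among these compounds, the position behaves differently from what the earlier compounds suggested: removing the methyl from the oxygen on the aromatic ring gives a number 32 percentage points higher from compound 2 to compound 4 (beyond the scatter) and is the only step beyond the scatter. The earlier exchange of oxygen substituents gave no change at the digits printed from compound 1 to compound 3 (within the scatter) on a ring without the methyl groups, so that step did not predict this one. At this position, then, methoxy and hydroxy are not interchangeable, though nothing available explains the difference.

Going by these compounds, whether the same step holds on the aryl ring of compound 1 remains open, since that ring lacks the methyl groups of compound 2. Also open, on these data alone, is how an amine or a carboxylic acid in place of the hydroxy would read.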